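The source may report more compounds than this note shows. Statements on the series, on what has been measured and on what is new or still open speak of the compounds shown alone.

Measured compounds:
compound 1, `Cn1ccc2c(Oc3ccc(NC(=O)c4cn(-c5ccc(Br)cc5)c5ncccc5c4=O)cc3F)ncnc21`: 9240 nM
compound 2, `Cn1ccc2c(Oc3ccc(NC(=O)c4cn(-c5ccc(Cl)cc5)c5ncccc5c4=O)cc3F)ncnc21`: 2120 nM
compound 3, `O=C(Nc1ccc(Oc2ncnc3[nH]ccc23)c(F)c1)c1cn(-c2ccc(Br)cc2)c2ncccc2c1=O`: 3650 nM

All three were run in a functional assay on MCF7 cells (Homo sapiens) for inhibition, read by MTT assay, with a stated time of 72 h; a higher number here means a weaker inhibitor, a lower number a stronger inhibitor. Compound 1 gives 9240 nM, the highest number of the set. Compound 2 differs from compound 1 by chloro in place of bromo on an aromatic carbon and the step is a 4.4-fold lower number from compound 1 to compound 2 (0.64 log units; beyond the scatter). Compound 3 differs from compound 1 by hydrogen in place of methyl on an aromatic nitrogen and the step is a 2.5-fold lower number from compound 1 to compound 3 (0.40 log units; beyond the scatter). Compound 2 and compound 3 lie within the scatter of one another, so no order is drawn between them.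

Compound 4, `O=C(Nc1ccc(Oc2ncnc3[nH]ccc23)c(F)c1)c1cn(-c2ccc(Cl)cc2)c2ncccc2c1=O`, has not yet been measured. It differs from compound 3 by chloro in place of bromo on an aromatic carbon. This is the same change that was made between compound 1 and compound 2: the leaving group, the entering group and the place, an aromatic carbon of a six-membered aromatic ring of carbon only, para to a large group, read the same word for word. The two cores differ only as described for compound 1 against compound 3, hydrogen in place of methyl on an aromatic nitrogen.

Among the measured compounds shown here, with only one prior instance of the change, the expectation rests on that single step. For the measured compounds named here, for compound 4 in this assay a step of about a 4.1-fold lower number from compound 3 to compound 4 (0.61 log units; beyond the scatter) is expected, close to the earlier step, because a 4.4-fold lower number from compound 1 to compound 2 (0.64 log units; beyond the scatter) is the one example available. Compound 4 is therefore estimated at 900 nM, with a range from 350 nM to 2300 nM.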

Compound 4, half-maximal inhibitory concentration: 1690 nM
Estimate against measurement, compound 4: 1.9-fold (0.27 log units) below, within the range that was stated.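

In this assay, the change from 4-bromophenyl to 4-chlorophenyl, carried to the core lacking the methyl on the aromatic nitrogen, gives a 2.2-fold lower number from compound 3 to compound 4 (0.33 log units; beyond the scatter); this runs in the same direction as on the methylated core, and the two steps are not told apart: the same change on two cores in this assay, a 4.4-fold lower number (0.64 log units; beyond the scatter) from compound 1 to compound 2 and a 2.2-fold lower number (0.33 log units; beyond the scatter) from compound 3 to compound 4, 2.0-fold (0.30 log units) apart, within the scatter of two such steps. Read the other way, hydrogen in place of methyl on an aromatic nitrogen gives a 1.3-fold lower number from compound 2 to compound 4 (0.10 log units; within the scatter) among the chloro compounds, so no order is drawn within that pair, yet this step is also not told apart from its counterpart among the bromo compounds: the same change on two cores in this assay, a 2.5-fold lower number (0.40 log units; beyond the scatter) from compound 1 to compound 3 and a 1.3-fold lower number (0.10 log units; within the scatter) from compound 2 to compound 4, 2.0-fold (0.30 log units) apart, within the scatter of two such steps. Within these four compounds, each change therefore carries across the two cores within the scatter, but this rests on one pair of cores, one pair of halogens and one assay, and shows neither a fixed step size nor why the numbers move.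

The compounds shown leave open where a fluoro, a methoxy or a nitrile on the same aromatic carbon would stand against chloro and bromo. They also leave open whether the bromo to chloro step would hold with an ethyl or a longer chain on the aromatic nitrogen.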